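The compounds below may be only part of what the source reports. "The series", "measured", "known", "first", "only" and "open" are said of these compounds alone.

Working notes on the series, read in an ADME assay on MT4 cells (Homo sapiens) for cytotoxicity, read by MTT assay; on this read-out lower numbers stand for higher toxicity in this test and higher numbers for lower toxicity in this test. Compound 1 `Cc1ccc(N(C(=O)c2c(F)cccc2F)C(=S)OCCN2C(=O)c3ccccc3C2=O)cc1` gives 65000 nM and compound 2 `Cc1ccc(N(C(=O)c2cc(F)cc(F)c2)C(=S)OCCN2C(=O)c3ccccc3C2=O)cc1` gives 54000 nM. For the measured compounds named here, compound 2 therefore stands within the scatter of the only other measured compound, and the two numbers cannot be ranked.

Next is compound 3 `Cc1ccc(N(C(=O)c2c(Cl)cccc2Cl)C(=S)OCCN2C(=O)c3ccccc3C2=O)cc1`, not yet measured in this assay. The change from compound 2 is 2,6-dichlorophenyl in place of 3,5-difluorophenyl on a carbonyl carbon. In words, this is 2,6-dichlorophenyl in place of 3,5-difluorophenyl on a carbonyl carbon.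

Going by the values given here, one measured step bears on this change, at the same place on the carbonyl carbon: 3,5-difluorophenyl in place of 2,6-difluorophenyl, a 1.2-fold lower number from compound 1 to compound 2 (0.08 log units; within the scatter). Among the compounds with values here, no measured step covers chlorine in place of fluorine, so that part of the change is untested. Within the data shown here, with only this small step as a guide, no shift beyond the scatter is expected in this assay, though the range has to stay wide. The expected step is a 1.1-fold lower number from compound 2 to compound 3 (0.03 log units; within the scatter). Compound 3 is estimated at 50000 nM, with an expected range of 20000 nM to 110000 nM.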

Compound 3, half-maximal cytotoxic concentration: 22000 nM
Estimate against measurement, compound 3: 2.3-fold (0.36 log units) above; measured number inside the range.
By their numbers in this assay, from the lowest: compound 3; then compounds 2 and 1 (each within the scatter of the next).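

In this assay the carbonyl carbon now shows a change beyond the scatter, with a 2.5-fold lower number from compound 2 to compound 3 (0.39 log units; beyond the scatter) and a 3.0-fold lower number from compound 1 to compound 3 (0.47 log units; beyond the scatter) among the compounds at this place, whereas the two difluorophenyl groups could not be separated. The second of these steps exchanges only fluorine for chlorine, so in these three compounds the position tolerates the two difluorophenyl groups without a readable difference, while 2,6-dichlorophenyl alone gives the lower number, which here stands for higher toxicity in this test, though the size of the shift remains modest. No measurement at hand accounts for this shift.

The compounds shown leave open whether the lower number goes with chlorine as such or with the 2,6-dichlorophenyl group as a whole, a question that 3,5-dichlorophenyl or 2,6-dimethylphenyl on the same carbonyl carbon would address. From the compounds shown here alone, all three compounds also share the rest of the core, so it remains open whether the step would carry over to a different group elsewhere on it, such as a longer chain.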